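The compounds below may be only part of what the source reports. "The series", "measured", "known", "first", "only" and "open" are said of these compounds alone.

Measured compounds:
Compound 1 `CCNC(=O)c1nnn(-c2cc(C(C)C)c(O)cc2O)c1-c1ccc(CN2CCC[C@H](O)C2)cc1` gives 70 nM in a functional assay on NCI-H460 cells (Homo sapiens) for inhibition, read by sulforhodamine B assay, with a stated time of 72 h; a lower number here means a stronger inhibitor, a higher number a weaker inhibitor.
Compound 2 `CCNC(=O)c1nnn(-c2cc(C(C)C)c(O)cc2O)c1-c1ccc(CN2CCN(C)CC2)cc1` gives 47 nM in this assay.

For the measured compounds named here, compound 1 stands at one end of these two numbers, its only neighbour being compound 2, and the step between them is a 1.5-fold lower number from compound 1 to compound 2 (0.17 log units; within the scatter). That single step is the only one that bears on the new compound: it exchanges the amine on the saturated chain carbon bound to the aromatic carbon, the same place that is altered here, and it produced no movement beyond the scatter.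

Compound 3 `CCNC(=O)c1nnn(-c2cc(C(C)C)c(O)cc2O)c1-c1ccc(CNC2CCN(C)CC2)cc1` differs from compound 1 by (1-methylpiperidin-4-yl)amino in place of 3-hydroxypiperidin-1-yl on a saturated chain carbon bound to an aromatic carbon. Going by the values given here, since the one comparable exchange at this position, from compound 1 to compound 2, stayed within the scatter, the expectation for this assay is a step of no real size in either direction, and the expected step is a 1.2-fold lower number from compound 1 to compound 3 (0.07 log units; within the scatter). Compound 3 is therefore estimated at 60 nM, with a range from 25 nM to 150 nM.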

Compound 3, half-maximal inhibitory concentration: > 1000 nM
Compound 3 ended at the assay's limit; the forecaster's own chance of this, stated with the estimate: 2%; middle value at least 16-fold (1.22 log units) from the limit.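

Compound 1 and compound 2 showed only that this saturated chain carbon bound to an aromatic carbon accepts 3-hydroxypiperidin-1-yl and 4-methylpiperazin-1-yl with no step beyond the scatter. The amine here is not freely exchangeable, however: in this assay, (1-methylpiperidin-4-yl)amino brings large steps from both earlier compounds (an at least 14-fold higher number from compound 1 to compound 3 (1.15 log units; beyond the scatter)) and (an at least 21-fold higher number from compound 2 to compound 3 (1.32 log units; beyond the scatter)). The value of compound 3 (> 1000 nM) is a limit of the assay and not a number: the limit of > 1000 nM in this assay, at which 1 of the 3 values shown sits.

The compounds shown leave open whether the loss follows the amino link or the 1-methylpiperidin-4-yl ring itself. A piperidin-4-ylamino group without the methyl, or a simple dimethylamino group, would bear on that question at this place.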